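A few compounds are considered here, and "the series" means these few. Any claim that something is new, unique, unknown or untested is made for them only; others in the source may bear on it.

Among the compounds with values here, compound 2 `O=c1[nH]c(=O)n([C@H]2C[C@H](O)[C@@H](CO)O2)cc1-c1cn(-c2ccc(OC(F)(F)F)cc2)nn1` carries a trifluoromethoxy group and in an ADME assay on HeLa cells (Homo sapiens) for cytotoxicity, read by cell counting, with a stated time of 4 days (a higher number here means a weaker inhibitor, a lower number a stronger inhibitor), gives 37000 nM, the higher of the two numbers measured so far. Compound 1 `O=c1[nH]c(=O)n([C@H]2C[C@H](O)[C@@H](CO)O2)cc1-c1cn(-c2ccc(Br)cc2)nn1` gives 1370 nM, and the step from it shows a 27-fold higher number from compound 1 to compound 2 (1.43 log units; beyond the scatter). Compound 3 `O=c1[nH]c(=O)n([C@H]2C[C@H](O)[C@@H](CO)O2)cc1-c1cn(-c2ccc(Oc3ccccc3)cc2)nn1` differs from compound 2 by phenyl in place of trifluoromethyl on an oxygen on an aromatic ring. Within the data shown here, no measured step exchanges these two groups on that oxygen, so the only guide is that a single change at this position has already shifted this assay markedly. For compound 3 the expected value is 20000 nM, in a range from 4000 nM to 100000 nM, which means a 1.9-fold lower number from compound 2 to compound 3 (0.27 log units; within the scatter) is expected.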

Compound 3, half-maximal inhibitory concentration: 280 nM
Estimate against measurement, compound 3: 71-fold (1.85 log units) above; measured number outside the range, below it.
By their numbers in this assay, from the lowest: compound 3; then compound 1; then compound 2.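

Changing the group on this oxygen moves the number strongly: phenyl in place of trifluoromethyl gives a 130-fold lower number from compound 2 to compound 3 (2.12 log units; beyond the scatter) in this series. Against bromo, phenoxy gives a 4.9-fold lower number from compound 1 to compound 3 (0.69 log units; beyond the scatter) while trifluoromethoxy went the other way, so the oxygen alone does not set the result, and what is attached to it matters. Nothing available here accounts for this spread. The compounds shown leave open how an amine or a carboxylic acid would read in place of these groups. As far as these compounds go, whether a longer chain on this oxygen would follow phenyl or trifluoromethyl also remains open.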